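This account rests on a few compounds, and the source may have more. Where it says the series, first, only, none or still open, it means among the compounds named here.

Measured in an ADME assay on microsomes from liver (Rattus norvegicus) for metabolic stability; a lower number here means that the compound disappears faster, a higher number that the compound lasts longer:
compound 1 `CCn1ncc2c(F)cc(-c3ccc(C(CC)(CC)c4nnc(C)[nH]4)c(=O)[nH]3)cc21`: > 3 h, a limit of this assay and not a number.
compound 2 `CC(C)[C@H](C[C@H]1CCNC1=O)c1ccc(-c2ccc3cccc(F)c3c2)[nH]c1=O`: 0.227 h
compound 3 `CC(C)C(c1ccc(-c2ccc3cccc(F)c3c2)[nH]c1=O)N1CCN/C1=N\C#N`: 0.327 h

Compound 1 stands at the limit of > 3 h in this assay, at which 1 of the 3 values shown sits, so only a lower bound on its half-life is known. The values of compound 2 and compound 3 sit far under that bound and lie within the scatter of each other. No step between measured compounds is shown, and nothing here tells how far past the limit compound 1 actually lies.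

Compound 4 `CCn1ncc2c(F)cc(-c3ccc(C(CC)(CC)c4nnc[nH]4)c(=O)[nH]3)cc21` differs from compound 1 by hydrogen in place of methyl on an aromatic carbon. In this assay the step of a number no higher from compound 1 to compound 4 (the limit leaves the size open) is expected to be none beyond the scatter, and the result is likely to come back again as a limit. Compound 4 is estimated at 3 h, in a range from 1.2 h to 6 h.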

Compound 4, half-life in the Rattus norvegicus assay: > 3 h
Compound 4: a limit, no number; the forecaster's own chance of this, stated with the estimate: 60%; the middle value lies on the limit itself.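

In the Rattus norvegicus assay, compound 1 and compound 4 both stand at a limit of the assay and not at a number, so no step can be read between them: the limit of > 3 h in the Rattus norvegicus assay, at which 2 of the 4 values shown sit.

In a physicochemical assay for solubility, in phosphate buffer, measured as kinetic solubility (a higher number here means a more soluble compound, a lower number a less soluble compound), compound 1 gives 26900 nM and compound 4 gives 35500 nM, two values within the scatter of each other.

Going by these compounds, how far past the limit the half-life of either compound lies stays open.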